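Working notes: compound 3 to compound 4 in the series

The compounds below may be only part of what the source reports. "The series", "measured", "known", "first", "only" and "open" are said of these compounds alone.

Measured so far in a functional assay on VCaP cells (Homo sapiens) for antiproliferative activity, read by CCK-8 assay, with a stated time of 6 days; a lower number here means a stronger inhibitor, a higher number a weaker inhibitor:
- compound 1 `CCN(c1ccc(C#N)c(Cl)c1)c1cc(-c2ccccc2)ccc1C` gives > 30000 nM, which is a limit of the assay and not a number.
- compound 2 `CCN(c1ccc(C#N)c(Cl)c1)c1cc(-c2cn[nH]c2)ccc1C` has "not determined" (no result reported) in this assay.
- compound 3 `CCN(c1ccc(C#N)c(Cl)c1)c1cc(-c2ccc(F)nc2)ccc1C` gives > 30000 nM, again a limit of the assay and not a number.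

Compound 3 therefore stands at the limit, where the limit of > 30000 nM in this assay, at which 2 of the 3 values shown sit, also holds. Within the data shown here, the step that the two limits leave unreadable from compound 1 to compound 3 is thus unreadable, and compound 2 brings no number at all, so no measured step in this assay carries a readable size.

Compound 4 `CCN(c1ccc(C#N)c(Cl)c1)c1cc(-n2cnc3ccccc32)ccc1C` differs from compound 3 in one place: 1H-benzimidazol-1-yl in place of 6-fluoropyridin-3-yl on an aromatic carbon. Among the measured compounds shown here, no measured step bears on this change; the only comparison among the measured compounds left its size unreadable.

With both measured values at the limit, the expectation for compound 4 is that it again reaches only the limit, so the expected step of an at least 1.2-fold lower number from compound 3 to compound 4 (0.07 log units; that floor lies within the scatter) is essentially none that can be read. The estimate for compound 4 is 25000 nM, with a range from 4000 nM to 60000 nM, and a limit rather than a number is the most likely report.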

Compound 4, half-maximal inhibitory concentration: 8560 nM
The estimate for compound 4 lay 2.9-fold (0.47 log units) above the measured number; the range from low to high includes it.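

In this assay, among these compounds, at this position, meta to a large group and para to a methyl group, 1H-benzimidazol-1-yl brings the first change with a readable direction, giving an at least 3.5-fold lower number from compound 3 to compound 4 (0.54 log units; beyond the scatter) and an at least 3.5-fold lower number from compound 1 to compound 4 (0.54 log units; beyond the scatter). The group on this aromatic carbon can therefore move the read-out, which the unreadable step from phenyl to 6-fluoropyridin-3-yl could not show. Both new steps are floors rather than full sizes, because the values of compound 1 and compound 3 are limits and not numbers: the limit of > 30000 nM in this assay, at which 2 of the 4 values shown sit.

The compounds shown do not separate the contribution of the six-membered carbon ring of 1H-benzimidazol-1-yl from that of its five-membered aromatic ring. They also leave open how an amine or a carboxylic acid on that ring system, or in its place on this carbon, would read.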